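Mouse liver microsome clearance: aryl to cyclopropyl amide

The compounds below may be only part of what the source reports. "The series", "measured", "known", "first", "only" and "open" are said of these compounds alone.

Measured so far:
compound 1 `CC(C)c1ccc(NC(=O)[C@H]2CN(C)C[C@@H]2c2ccc(/C=C/C(=O)Nc3ccccc3N)cc2)cc1`: 54 mL/min/kg
compound 2 `COc1cccc(NC(=O)[C@H]2CN(C)C[C@@H]2c2ccc(/C=C/C(=O)Nc3ccccc3N)cc2)c1`: 65 mL/min/kg

For the measured compounds named here, in an in vitro ADME assay on microsomes from liver (Mus musculus) for pharmacokinetics, read by LC-MS, with a stated time of 10 min, tested at 1 uM (on this read-out higher numbers stand for fast clearance and lower numbers for slow clearance), compound 2 gives 65 mL/min/kg, the higher of the two numbers so far, with compound 1 nearest at 54 mL/min/kg; the two lie within the scatter of each other, so no order between them is claimed.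

Compound 3 `CN1C[C@H](C(=O)NC2CC2)[C@@H](c2ccc(/C=C/C(=O)Nc3ccccc3N)cc2)C1` is the next member of the series. It differs from compound 2 by cyclopropyl in place of 3-methoxyphenyl on an amide-type nitrogen.

Going by the values given here, only one measured step exists, a 1.2-fold higher number from compound 1 to compound 2 (0.08 log units; within the scatter), and it exchanges one aryl group for another on the amide-type nitrogen; it does not reach the change to cyclopropyl. Among the compounds with values here, it shows that the two aryl amides sit close together in this assay, and no measured step bears directly on the step from compound 2 to compound 3. On that basis no shift beyond the scatter is expected, and the estimate for compound 3 is 48 mL/min/kg (range 25 mL/min/kg to 90 mL/min/kg), which as a step is an expected 1.4-fold lower number from compound 2 to compound 3 (0.13 log units; within the scatter).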

Compound 3, clearance: 7 mL/min/kg
Beside the measured number, compound 3's estimate is 6.9-fold (0.84 log units) above it; the measured number lies below the stated range.
By their numbers in this assay, from the lowest: compound 3; then compounds 1 and 2 (each within the scatter of the next).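

In this assay, the amide-type nitrogen turns out to be a place where the number can move well beyond the scatter: a 9.3-fold lower number from compound 2 to compound 3 (0.97 log units; beyond the scatter), and a 7.7-fold lower number from compound 1 to compound 3 (0.89 log units; beyond the scatter), with cyclopropyl entering in place of each aryl group. The exchange of one aryl group for another gave no such separation, at a 1.2-fold higher number from compound 1 to compound 2 (0.08 log units; within the scatter), so among these three compounds the large difference appears only on going from a six-membered aromatic ring to a three-membered non-aromatic ring. Nothing at hand accounts for the drop.

Only one non-aromatic group on this nitrogen is shown, so it remains open whether the low number is particular to cyclopropyl. A cyclobutyl group, a tert-butyl group or an unbranched longer chain at the same place would test how far it extends.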